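Two Inactive Ureas and an Aryl Urea Yet to Test

The source may report more compounds than this note shows. Statements on the series, on what has been measured and on what is new or still open speak of the compounds shown alone.

Compound 1 `CCN1CCc2c(sc(NC(=O)NCC3CCCO3)c2C(N)=O)C1` — in a functional assay (strain AB) with Danio rerio as the target, read by microscopy, with a stated time of 1 h (a higher number here means that more compound is needed for the effect, a lower number that less compound is needed), compound 1 gives > 25000 nM, which is a limit of the assay and not a number.
Compound 2 `CCN1CCc2c(sc(NC(=O)CN3CCCCC3)c2C(N)=O)C1` — in this assay compound 2 gives > 25000 nM, again a limit rather than a number.

Compound 2 therefore stands at the edge of what this assay can report, with no measured number of its own. Within the data shown here, the one step between measured compounds, a step that the two limits leave unreadable from compound 1 to compound 2, cannot be read, since both ends sit at the limit (the limit of > 25000 nM in this assay, at which 2 of the 2 values shown sit).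

The unmeasured compound 3 `CCN1CCc2c(sc(NC(=O)Nc3ccc(Br)cc3)c2C(N)=O)C1` differs from compound 2 in one place: (4-bromophenyl)amino in place of (piperidin-1-yl)methyl on a carbonyl carbon. Among the measured compounds shown here, no measured step bears on this change, because the only step in the set, a step that the two limits leave unreadable from compound 1 to compound 2, is itself unreadable. With both measured compounds at the limit and nothing to show the direction of an amide-to-urea change, compound 3 is expected to remain near the limit, and the step of an at least 1.2-fold lower number from compound 2 to compound 3 (0.09 log units; that floor lies within the scatter) is estimated to be no larger than the scatter. Compound 3 is thus expected at about 20000 nM, within 3000 nM to 100000 nM.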

Compound 3, half-maximal effective concentration: 3130 nM
Beside the measured number, compound 3's estimate is 6.4-fold (0.81 log units) above it; low and high end bracket the measured number.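

In this assay, compound 3 is the only one of the three to give a number rather than a limit, which shows that the group on this carbonyl carbon can move the read-out: (4-bromophenyl)amino in place of (piperidin-1-yl)methyl gives an at least 7.9-fold lower number from compound 2 to compound 3 (0.90 log units; beyond the scatter). Read as a change on the amide-type nitrogen of the urea, 4-bromophenyl in place of (oxolan-2-yl)methyl gives an at least 7.9-fold lower number from compound 1 to compound 3 (0.90 log units; beyond the scatter), so the same compound stands clear of both inactive neighbours, one a urea and one an amide. The step between compound 1 and compound 2 still cannot be read, and the two new steps give only floors, not full sizes, since each starts from a compound at the limit: the limit of > 25000 nM in this assay, at which 2 of the 3 values shown sit.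

The compounds shown do not separate the share of the bromine from that of the aromatic ring, as no plain phenyl, 4-chlorophenyl or 4-methoxyphenyl group stands on that nitrogen. They also leave open how the number responds to changes elsewhere on the shared core, such as a nitrile or a carboxylic acid in place of the primary carboxamide, or a longer chain in place of the ethyl group.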